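A few compounds are considered here, and "the series" means these few. Any claim that something is new, unique, unknown or untested is made for them only; others in the source may bear on it.

Measured compounds:
Compound 1, `Cn1cncc1CN1CC(N(CC2CCN(C(=O)c3ccc(Cl)cc3)CC2)S(=O)(=O)c2ccccn2)Cc2cc(C#N)ccc21`, gives 0.5 10^-6 cm/s in an ADME assay on Caco-2 cells (Homo sapiens) for permeability, in the apical to basolateral direction; on this read-out higher numbers stand for higher permeability and lower numbers for lower permeability.
Compound 2, `Cn1cncc1CN1CC(N(CC2CCN(S(C)(=O)=O)CC2)S(=O)(=O)c2ccccn2)Cc2cc(C#N)ccc21`, gives 0.1 10^-6 cm/s in this assay.

Within the data shown here, compound 2 holds the lowest of the two numbers in this assay; its only neighbour is compound 1, and the step of a 5.0-fold lower number from compound 1 to compound 2 (0.70 log units; beyond the scatter) lies beyond the scatter. That step exchanged (4-chlorophenyl)carbonyl for methylsulfonyl on an amine nitrogen in a ring, and the number fell.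

Compound 3, `Cn1cncc1CN1CC(N(CC2CCN(C(=O)Nc3ccc(Br)cc3)CC2)S(=O)(=O)c2ccccn2)Cc2cc(C#N)ccc21`, has not yet been measured in this assay. It differs from compound 2 in one place: (4-bromophenyl)carbamoyl in place of methylsulfonyl on an amine nitrogen in a ring. The methylsulfonyl group is thus removed again and a group bearing a six-membered aromatic ring enters at the same amine nitrogen in a ring, much as in compound 1, though here as a carbamoyl with a hydrogen-bond donor rather than a carbonyl.

Among the measured compounds shown here, only the step from compound 1 to compound 2 bears on this change, and it is walked here in the reverse sense. A rise beyond the scatter is therefore expected, of roughly that size, bringing compound 3 back toward compound 1. For compound 3 the expected step is a 4.0-fold higher number from compound 2 to compound 3 (0.60 log units; beyond the scatter). Compound 3 is estimated at 0.4 10^-6 cm/s, with a range from 0.15 10^-6 cm/s to 1.2 10^-6 cm/s.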

Compound 3, apparent permeability: 0.6 10^-6 cm/s
Beside the measured number, compound 3's estimate is 1.5-fold (0.18 log units) below it, and the stated range covers the measured number.
By their numbers in this assay, from the lowest: compound 2; then compounds 1 and 3 (each within the scatter of the next).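

At this amine nitrogen in a ring, (4-bromophenyl)carbamoyl in place of methylsulfonyl gives a 6.0-fold higher number from compound 2 to compound 3 (0.78 log units; beyond the scatter) in this assay, so the low number of compound 2 now stands against two different groups that bear a six-membered aromatic ring, not just one. The link between those two groups matters little here: with a 1.2-fold higher number from compound 1 to compound 3 (0.08 log units; within the scatter), the carbamoyl of compound 3, with its hydrogen-bond donor and bromine, cannot be told apart on this read-out from the carbonyl and chlorine of compound 1. No measurement is available that would explain either step.

Going by these compounds, compounds 1 and 3 each carry both an aromatic ring and a halogen, so it stays open whether the ring, the halogen or the larger size of the group goes with the higher numbers; an unsubstituted benzoyl or a small acetyl on the same nitrogen would begin to separate these. These three compounds differ only at this nitrogen, so they also leave open how changes elsewhere on the shared core would bear on the number.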